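From 4-methoxybenzyl to hexyl in a mouse assay

The source may report more compounds than this note shows. Statements on the series, on what has been measured and on what is new or still open speak of the compounds shown alone.

Compound 1 `CCCn1c(=O)n(C2CCC(COC(C)=O)O2)c2nc(NC(C)=O)nc(O)c21`: 80 uM
Compound 2 `C=CCn1c(=O)n([C@H]2CO[C@@H](CO)C2)c2nc(N)nc(O)c21`: 272 uM
Compound 3 `COc1ccc(Cn2c(=O)n(C3OC(CO)[C@@H](O)[C@H]3O)c3nc(N)nc(O)c32)cc1`: 2 uM

All three values come from a functional assay with Mus musculus as the target; a higher number here means that more compound is needed for the effect, a lower number that less compound is needed. Compound 3 has the lowest number of the set at 2 uM, and both other compounds lie well beyond the scatter from it. The next compound to be measured is compound 4 `CCCCCCn1c(=O)n(C2OC(CO)[C@@H](O)[C@H]2O)c2nc(N)nc(O)c21`. It has pentyl in place of 4-methoxyphenyl on a saturated chain carbon bound to an aromatic nitrogen.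

Among the compounds with values here, no two measured compounds differ in only one place, so the data do not show the effect of this change directly. Within the data shown here, the only guide is indirect. Compound 1 at 80 uM and compound 2 at 272 uM also lack the 4-methoxyphenyl group and need more compound, but they differ from compound 3 elsewhere too. A moderate rise in the number, beyond the scatter, is therefore expected in this assay. The estimated step is a 6.0-fold higher number from compound 3 to compound 4 (0.78 log units; beyond the scatter). For compound 4 the expected value is 12 uM, with an estimated range from 3 uM to 60 uM.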

Compound 4, concentration for half-maximal effect: 600 uM
For compound 4 the middle estimate is 50-fold (1.70 log units) below the measured one; measured number above the stated range.
By their numbers in this assay, from the lowest: compound 3; then compound 1; then compound 2; then compound 4.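

In this assay pentyl in place of 4-methoxyphenyl on a saturated chain carbon bound to an aromatic nitrogen gives a 300-fold higher number from compound 3 to compound 4 (2.48 log units; beyond the scatter) as a large step beyond the scatter. Within the data shown here, this is the first direct reading of this position, since compound 3 and compound 4 differ in this one place, whereas the earlier compounds differed in several places at once. It shows that this change alone can move the number strongly, but no available evidence accounts for the size of the step.

The compounds shown leave open whether the step follows the loss of the aromatic ring, the loss of the methoxy oxygen or the entry of the chain. Benzyl or 4-methylbenzyl at this position on the core of compound 3 would separate these readings.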